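Expected effect of 2,4-difluorophenyl in place of 2,4-dichlorophenyl

The compounds below may be only part of what the source reports. "The series", "measured", "known", "first", "only" and "open" are said of these compounds alone.

In a functional assay on U-251 cells (Homo sapiens) (a lower number here means a stronger inhibitor of growth, a higher number a weaker inhibitor of growth), compound 3 (`O=S(=O)(/C=C/c1ccc(Cl)cc1Cl)Cc1ccc(Nc2ncnc3ccccc23)cc1`) gives 4000 nM and holds the middle place among the three measured numbers. Compound 2 (`O=S(=O)(/C=C/c1ccc(Cl)c(Cl)c1)Cc1ccc(Nc2ncnc3ccccc23)cc1`) gives 11000 nM as the highest number, and compound 1 (`O=S(=O)(/C=C/c1ccc(F)cc1)Cc1ccc(Nc2ncnc3ccccc23)cc1`) gives 10 nM as the lowest.

Compound 4 (`O=S(=O)(/C=C/c1ccc(F)cc1F)Cc1ccc(Nc2ncnc3ccccc23)cc1`) differs from compound 3 as follows: 2,4-difluorophenyl in place of 2,4-dichlorophenyl on a double-bonded chain carbon bound to a double-bonded chain carbon with 2,4-difluorophenyl in place of 2,4-dichlorophenyl on a double-bonded chain carbon bound to a double-bonded chain carbon.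

For the measured compounds named here, no measured step makes this exact swap. The large step of a 400-fold higher number from compound 1 to compound 3 (2.60 log units; beyond the scatter) comes with 2,4-dichlorophenyl in place of 4-fluorophenyl, and the large step of a 1100-fold higher number from compound 1 to compound 2 (3.04 log units; beyond the scatter) comes with 3,4-dichlorophenyl in place of 4-fluorophenyl. The step of a 2.8-fold lower number from compound 2 to compound 3 (0.44 log units; beyond the scatter) between the two dichlorophenyl groups is only modest. The three compounds cannot show how much of the large steps follows the change of halogen and how much the change in substitution, so the expectation remains loose.

The expected step is a 20-fold lower number from compound 3 to compound 4 (1.30 log units; beyond the scatter) in this assay and points towards compound 1 without being expected to cover the whole distance. For compound 4 the estimate is 200 nM with an expected range from 20 nM to 2500 nM until the measurement is available.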

Compound 4, concentration for 50% growth inhibition: > 100000 nM
Compound 4 gave a limit, no number; the forecaster's own chance of this, stated with the estimate: 3%; middle value at least 500-fold (2.69 log units) from the limit.
By their numbers in this assay, from the lowest: compound 1; then compound 3; then compound 2. At a limit, above all of these: compound 4.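

In this assay compound 4 gives a limit of the assay and not a number: the limit of > 100000 nM in this assay, at which 1 of the 4 values shown sits. The 2,4-difluorophenyl group does not behave like 4-fluorophenyl, with an at least 10000-fold higher number from compound 1 to compound 4 (4.00 log units; beyond the scatter), so on this double-bonded chain carbon one added fluoro is enough to lose the low number of compound 1, and the presence of fluoro alone does not secure it. Replacing 2,4-dichlorophenyl with 2,4-difluorophenyl gives an at least 25-fold higher number from compound 3 to compound 4 (1.39 log units; beyond the scatter), and replacing 3,4-dichlorophenyl with it gives an at least 9.0-fold higher number from compound 2 to compound 4 (0.95 log units; beyond the scatter), so among these four compounds only the group with a single halogen gives a low number, the three groups with two halogens all give high numbers, and none of the four goes against this.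

The compounds shown leave open whether the low number of compound 1 depends on fluoro itself or on the phenyl ring carrying a single substituent, which 4-chlorophenyl, 2-fluorophenyl and unsubstituted phenyl at this place would separate. A 4-methoxyphenyl group would show whether a group other than a halogen can keep the low number here.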